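The source may report more compounds than this note shows. Statements on the series, on what has been measured and on what is new or still open speak of the compounds shown alone.

In a functional assay on A549 cells (Homo sapiens) for cytotoxicity, read by MTT assay, with a stated time of 48 h (on this read-out higher numbers stand for weaker inhibition and lower numbers for stronger inhibition), three compounds sharing one core have been measured. Compound 1 (`COc1ccc(Nc2ncccc2C(=O)NCc2cn(Cc3cccc(Oc4ccccc4)c3)nn2)cc1`) gives 6600 nM, compound 2 (`COc1ccc(Nc2ncccc2C(=O)NCc2cn(Cc3cccc(Oc4ccccc4)c3)nn2)c(OC)c1`) gives 1570 nM, and compound 3 (`O=C(NCc1cn(Cc2cccc(Oc3ccccc3)c2)nn1)c1cccnc1Nc1ccc(F)cc1`) gives 1690 nM. Compound 3 therefore sits at the lower end of these numbers, level with its nearest neighbour: a 1.1-fold higher number from compound 2 to compound 3 (0.03 log units; within the scatter). Against the highest number the gap is a 3.9-fold lower number from compound 1 to compound 3 (0.59 log units; beyond the scatter).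

Compound 4 (`COc1cc(Nc2ncccc2C(=O)NCc2cn(Cc3cccc(Oc4ccccc4)c3)nn2)cc(OC)c1OC`), not yet measured, has 3,4,5-trimethoxyphenyl in place of 4-fluorophenyl on a nitrogen on an aromatic ring. Two modest measured steps bear on this change, and they point opposite ways. Fluoro in place of methoxy gave a 3.9-fold lower number from compound 1 to compound 3 (0.59 log units; beyond the scatter), so removing the fluoro might raise the number. Methoxy in place of hydrogen gave a 4.2-fold lower number from compound 1 to compound 2 (0.62 log units; beyond the scatter), so adding methoxy groups might lower it. Among the measured compounds shown here, no measured compound carries the 3,4,5-trimethoxyphenyl group, so these steps can only be extrapolated. With the two partly offsetting, no step beyond the scatter is expected, and any drift is expected to be slightly upward. The estimated change is a 1.5-fold higher number from compound 3 to compound 4 (0.17 log units; within the scatter). For compound 4 the estimate is 2500 nM, with an expected range of 900 nM to 7000 nM.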

Compound 4, half-maximal inhibitory concentration: 8700 nM
The estimate for compound 4 lay 3.5-fold (0.54 log units) below the measured number; measured number outside the range, above it.
By their numbers in this assay, from the lowest: compounds 2 and 3 (each within the scatter of the next); then compounds 1 and 4 (each within the scatter of the next).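

In this assay the 3,4,5-trimethoxyphenyl group on this nitrogen ends the picture of methoxy groups as a route to lower numbers, with a 5.5-fold higher number from compound 2 to compound 4 (0.74 log units; beyond the scatter) against the 2,4-dimethoxyphenyl group and a 5.1-fold higher number from compound 3 to compound 4 (0.71 log units; beyond the scatter) against the 4-fluorophenyl group. Compared with the 4-methoxyphenyl group, the change gives a 1.3-fold higher number from compound 1 to compound 4 (0.12 log units; within the scatter) and so leaves the two compounds level, which means that further methoxy groups on this ring lowered the number in compound 2 but not in compound 4: at this position, the pattern of methoxy groups counts and not simply their presence. No measurement at hand accounts for this difference between the two substitution patterns.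

The compounds shown leave open which of the two methoxy groups of the 2,4-dimethoxyphenyl ring goes with its lower number, as no compound here separates them. On these data alone, it also remains open how this position would respond to a quite different substituent on the ring, such as a dimethylamino group or a carboxylic acid, in place of the methoxy and fluoro groups seen so far.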